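Carboxy to hydroxymethyl on the piperidine side chain

The source may hold more compounds than are shown below. What is called first, only, known or untested is meant among the compounds shown, and "the series" means these compounds.

Among the measured compounds shown here, compound 3 `Cn1ncc(Cl)c1-c1cc(C(=O)N[C@@H]2CN[C@H](CC(=O)O)C[C@H]2c2ccc(Cl)c(Cl)c2)oc1Cl` gives 1.94 nM in an assay for inhibition of RAC-alpha serine/threonine-protein kinase (Homo sapiens), read by HTRF, with a stated time of 1 h (on this read-out lower numbers stand for stronger inhibition and higher numbers for weaker inhibition), the lowest number among the three measured members. Its nearest neighbour is compound 2 `Cn1ncc(Cl)c1-c1cc(C(=O)N[C@@H]2CN[C@H](CCCO)C[C@H]2c2ccc(Cl)c(Cl)c2)oc1Cl` at 2.56 nM; the gap a 1.3-fold lower number from compound 2 to compound 3 (0.12 log units; within the scatter) lies within the scatter. Compound 1 `Cn1ncc(Cl)c1-c1cc(C(=O)N[C@@H]2CN[C@H](CCN3CCC(O)CC3)C[C@H]2c2ccc(Cl)c(Cl)c2)oc1Cl` stands furthest away at 5.99 nM, with a 3.1-fold lower number from compound 1 to compound 3 (0.49 log units; beyond the scatter) and a 2.3-fold lower number from compound 1 to compound 2 (0.37 log units; beyond the scatter) both beyond the scatter.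

Compound 4 `Cn1ncc(Cl)c1-c1cc(C(=O)N[C@@H]2CN[C@H](CCO)C[C@H]2c2ccc(Cl)c(Cl)c2)oc1Cl` carries hydroxymethyl in place of carboxy on a saturated chain carbon bound to a saturated ring carbon. For the measured compounds named here, the steps that bear on it are the two ending in compound 3: the change from a 2-hydroxyethyl to carboxy, a 1.3-fold lower number from compound 2 to compound 3 (0.12 log units; within the scatter), and from a (4-hydroxypiperidin-1-yl)methyl to carboxy, a 3.1-fold lower number from compound 1 to compound 3 (0.49 log units; beyond the scatter). Compound 4 places a hydroxyl-bearing group at the same chain carbon as the 2-hydroxyethyl of compound 2, one bond closer, and compound 2 sits within the scatter of compound 3. The expectation for the step is therefore no movement beyond the scatter, with a slight lean toward a higher number, a 1.5-fold higher number from compound 3 to compound 4 (0.19 log units; within the scatter).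

Compound 4 is estimated at 3 nM in this assay, with a range of 1.4 nM to 6.5 nM, the estimate being anchored on compound 2 at 2.56 nM and compound 3 at 1.94 nM.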

Compound 4, half-maximal inhibitory concentration: 2.74 nM
Compound 4: middle estimate off by 1.1-fold (0.04 log units), on the high side; the measured number falls inside the stated range.
By their numbers in this assay, from the lowest: compounds 3, 2 and 4 (each within the scatter of the next); then compound 1.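

In this assay, hydroxymethyl in place of carboxy on the saturated chain carbon bound to a saturated ring carbon gives a 1.4-fold higher number from compound 3 to compound 4 (0.15 log units; within the scatter) and so leaves the read-out within the scatter, which shows that the carboxy group is not needed at this position to stay level with compound 3. The hydroxyl-ended chains also cannot be told apart by length, with a 1.1-fold higher number from compound 2 to compound 4 (0.03 log units; within the scatter) as the read-out for the shorter chain, while a 2.2-fold lower number from compound 1 to compound 4 (0.34 log units; beyond the scatter) stays beyond the scatter, so compounds 2, 3 and 4 now form one level, with only compound 1 and its 4-hydroxypiperidin-1-yl group set apart. No measurement at hand accounts for either the shared level or the gap to compound 1.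

As far as these compounds go, whether a primary amine or a primary amide at the chain end would stay on that level remains open, as does the reading for a methyl ether in place of the hydroxyl. A dimethylamino group on the same chain would help separate the contribution of the amine nitrogen in compound 1 from that of its ring.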